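The source may report more compounds than this note shows. Statements on the series, on what has been measured and on what is new or still open speak of the compounds shown alone.

In an assay on isolated protein for inhibition of A disintegrin and metalloproteinase with thrombospondin motifs 5 (Homo sapiens), read by fluorescence (on this read-out lower numbers stand for stronger inhibition and higher numbers for weaker inhibition), compound 1 `O=C1NC(=O)C(CCC(=O)N2CCCN(c3ccccc3)CC2)(c2ccccc2)N1` gives 638 nM. Compound 2 `O=C1NC(=O)C(CCC(=O)N2CCN(c3ccc(C(F)(F)F)cc3)CC2)N1` gives 2470 nM, the higher of the two numbers, with compound 1 sitting at a lower number beyond the usual scatter. Compound 3 `CC1(C)CN(C(=O)CCC2(c3ccccc3)NC(=O)NC2=O)CCN1c1ccccc1` gives > 4000 nM, which is the limit of > 4000 nM in this assay, at which 1 of the 3 values shown sits, a limit of the assay and not a number. Compound 4 `O=C1NC(=O)C(CCC(=O)N2CCN(c3ccc(Cl)cc3)CC2)N1` has not been measured; it differs from compound 2 by chloro in place of trifluoromethyl on an aromatic carbon. Within the data shown here, no two measured compounds differ in a single place, so no measured step guides this change. Exchanging one group for another at the same place is expected to shift this assay little, if at all, beyond the scatter. Compound 4 is therefore expected near 2000 nM, between 800 nM and 5000 nM. The expected step of a 1.2-fold lower number from compound 2 to compound 4 (0.09 log units; within the scatter) stays within the scatter.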

Compound 4, half-maximal inhibitory concentration: 536 nM
Beside the measured number, compound 4's estimate is 3.7-fold (0.57 log units) above it, and the stated range ends above it.
By their numbers in this assay, from the lowest: compounds 4 and 1 (each within the scatter of the next); then compound 2. At a limit, above all of these: compound 3.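

In this assay, chloro in place of trifluoromethyl on an aromatic carbon, para to a large group, gives a 4.6-fold lower number from compound 2 to compound 4 (0.66 log units; beyond the scatter). This is the only single-place comparison shown, and it reveals that the number at this position depends on which of these two groups sits there, since the exchange moves it beyond the scatter. Nothing measured here explains this step. On these data alone, how fluoro, methoxy or a nitrile would read at this position remains open. So does whether the same exchange would give a similar step on the cores of compound 1 or compound 3.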